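From pyridin-4-yl to 3,4-dichlorophenyl on a shared core

The source may report more compounds than this note shows. Statements on the series, on what has been measured and on what is new or still open speak of the compounds shown alone.

Compound 1 `COc1cc(C(=O)c2sc(-c3cccc([N+](=O)[O-])c3)cc2N)cc(OC)c1OC`: 11 nM
Compound 2 `COc1cc(C(=O)c2sc(-c3ccccc3)cc2N)cc(OC)c1OC`: 11 nM
Compound 3 `COc1cc(C(=O)c2sc(-c3ccncc3)cc2N)cc(OC)c1OC`: 1810 nM

All three compounds were tested in a functional assay on L1210 cells (Mus musculus) for antiproliferative activity; on this read-out higher numbers stand for weaker inhibition and lower numbers for stronger inhibition. Compound 3 holds the highest of the three numbers at 1810 nM, and its steps to both of the others lie beyond the scatter. Compound 4 `COc1cc(C(=O)c2sc(-c3ccc(Cl)c(Cl)c3)cc2N)cc(OC)c1OC` has not yet been measured. It departs from compound 3 at a single place: 3,4-dichlorophenyl in place of pyridin-4-yl on an aromatic carbon.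

Within the data shown here, three measured steps bear on this change. Putting pyridin-4-yl in place of phenyl gave a 160-fold higher number from compound 2 to compound 3 (2.22 log units; beyond the scatter), and putting it in place of 3-nitrophenyl gave a 160-fold higher number from compound 1 to compound 3 (2.22 log units; beyond the scatter). Hydrogen in place of nitro gave no change at the digits printed from compound 1 to compound 2 (within the scatter). Compound 4 shares with compound 1 and compound 2 a six-membered aromatic ring of carbon only at this place, and neither of those two compounds goes against the low numbers seen with such a ring. Among the measured compounds shown here, no measured compound carries chlorine, however, so the effect of the two chlorines on the number is unknown. A large step to a lower number is therefore expected in this assay, possibly falling somewhat short of the full measured size. The estimated step is a 60-fold lower number from compound 3 to compound 4 (1.78 log units; beyond the scatter). Compound 4 is expected at 30 nM, with an estimated range from 8 nM to 200 nM.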

Compound 4, half-maximal inhibitory concentration: 260 nM
Estimate against measurement, compound 4: 8.7-fold (0.94 log units) below; the measured number lies above the stated range.
By their numbers in this assay, from the lowest: compounds 1 and 2 (each within the scatter of the next); then compound 4; then compound 3.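

In this assay, 3,4-dichlorophenyl in place of pyridin-4-yl gives a 7.0-fold lower number from compound 3 to compound 4 (0.84 log units; beyond the scatter) and so keeps compound 4 on the lower side of the pyridin-4-yl compound, which fits the low numbers seen with a six-membered aromatic ring of carbon only at this place. That ring alone, however, does not settle the number: 3,4-dichlorophenyl gives a 24-fold higher number from compound 2 to compound 4 (1.37 log units; beyond the scatter) and likewise a 24-fold higher number from compound 1 to compound 4 (1.37 log units; beyond the scatter), whereas the earlier exchange of nitro for hydrogen gave no change at the digits printed from compound 1 to compound 2 (within the scatter), so what the ring carries can matter a great deal in this assay, at least for the two chlorines. No measured property of these compounds is at hand to account for this gap.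

The compounds shown leave open whether both chlorines are needed for the higher number, since 3-chlorophenyl and 4-chlorophenyl would separate the contribution of each one. They also leave open whether the shift belongs to chlorine itself or would recur with other groups on the ring, such as methyl, methoxy or an amine.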